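From compound 3 to compound 4: a ring enters

The source may report more compounds than this note shows. Statements on the series, on what has been measured and on what is new or still open speak of the compounds shown alone.

Measured in a functional assay on MCF7 cells (Homo sapiens) for inhibition, read by MTT assay, with a stated time of 48 h; on this read-out higher numbers stand for weaker inhibition and lower numbers for stronger inhibition:
- compound 1 `CCOC(=O)C1=C(NN=C(C(C)=O)C(C)=O)Nc2[nH]nc(C)c2C1c1ccc(N(C)C)cc1`: 9740 nM
- compound 2 `CCOC(=O)C1=C(N/N=C(/C#N)C(=O)OCC)Nc2[nH]nc(C)c2C1c1ccc(N(C)C)cc1`: 35600 nM
- compound 3 `CCOC(=O)C1=C(N/N=C(\C#N)C(N)=O)Nc2[nH]nc(C)c2C1c1ccc(N(C)C)cc1`: 50100 nM

Compound 3 stands level with compound 2 within the scatter, a 1.4-fold higher number from compound 2 to compound 3 (0.15 log units; within the scatter), and apart from compound 1, a 5.1-fold higher number from compound 1 to compound 3 (0.71 log units; beyond the scatter). Compound 2 is also apart from compound 1: a 3.7-fold higher number from compound 1 to compound 2 (0.56 log units; beyond the scatter). Compound 4 `CCOC(=O)C1=C(N/N=C(/C(=O)Br)c2ccc(Br)cc2)Nc2[nH]nc(C)c2C1c1ccc(N(C)C)cc1` differs from compound 3 by one change: a group of 12 heavy atoms (8 carbon, 1 nitrogen, 1 oxygen, 2 bromine; one six-membered aromatic ring of carbon only) in place of a group of 7 heavy atoms (3 carbon, 3 nitrogen, 1 oxygen; no ring), on an amine nitrogen. From the compounds shown here alone, all three measured steps swap groups at this same place, but none of those groups holds a ring, so the new group is untested. Compound 1 shows how far a swap here has moved the number, a 5.1-fold higher number from compound 1 to compound 3 (0.71 log units; beyond the scatter). The expected step is therefore modest, toward a lower number: a 2.5-fold lower number from compound 3 to compound 4 (0.40 log units; beyond the scatter). In this assay, compound 4 is estimated at 20000 nM, with a range of 6000 nM to 60000 nM.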

Compound 4, half-maximal inhibitory concentration: 61300 nM
Compound 4: middle estimate off by 3.1-fold (0.49 log units), on the low side, outside the stated range (above it).
By their numbers in this assay, from the lowest: compound 1; then compounds 2, 3 and 4 (each within the scatter of the next).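

In this assay, among these compounds, the first group on this amine nitrogen to hold a six-membered aromatic ring, along with two bromine atoms, gives no clear change from two ring-free groups (a 1.2-fold higher number from compound 3 to compound 4 (0.09 log units; within the scatter)) and (a 1.7-fold higher number from compound 2 to compound 4 (0.24 log units; within the scatter)). Only the comparison with the group of compound 1 lies beyond the scatter (a 6.3-fold higher number from compound 1 to compound 4 (0.80 log units; beyond the scatter)), so adding this ring brings no lower number here. Nothing available explains this result. The ring and bromine atoms arrive together, so their separate contributions cannot be told apart. From the compounds shown here alone, how a plain phenyl ring, or one carrying an amine or a carboxylic acid, would behave remains open.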